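Swapping Methyl for Acetyl on the Amine Nitrogen

This account rests on a few compounds, and the source may have more. Where it says the series, first, only, none or still open, it means among the compounds named here.

Of the compounds shown here, three have been measured in a functional assay on cells (mast cells, Rattus norvegicus, strain Wistar) for inhibition, with Mast cell (Mus musculus) as the target, tested at 10 uM; on this read-out higher numbers stand for more inhibition at the one concentration tested (going by the name of the read-out) and lower numbers for less inhibition. Compound 1 `C=CCN(C1=CC(=O)c2ccccc21)C1CCc2ccccc21` gives 79.9%. Where compound 1 carries an allyl, an acetyl sits instead in compound 2 `CC(=O)N(C1=CC(=O)c2ccccc21)C1CCc2ccccc21`, and in this assay compound 2 gives 14.3%, so that a number 65.6 percentage points lower from compound 1 to compound 2 (beyond the scatter). Compound 3 `CN(C1=CC(=O)c2ccccc21)C1CCCC1` gives 85.6%, the highest of the three numbers, though compound 1 lies within the scatter of it, while compound 2 lies far beyond.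

Compound 4 `CC(=O)N(C1=CC(=O)c2ccccc21)C1CCCC1` is not yet measured. Compared with compound 3, the change is acetyl in place of methyl on an amine nitrogen. Among the compounds with values here, the one measured step that bears on this, from compound 1 to compound 2, also put an acetyl onto the same amine nitrogen, and it brought a large fall in this assay. The same kind of change is therefore expected to lower the number for compound 4 well beyond the scatter, an estimated step of a number 67.6 percentage points lower from compound 3 to compound 4 (beyond the scatter). Compound 4 is thus expected to give about 18%, within a range from 5% to 40%.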

Compound 4, a percentage reported as inhibition, at one concentration (the size of the read-out at that concentration, not a potency): -0.9%
Beside the measured number, compound 4's estimate is 18.9 percentage points above it; measured number outside the range, below it.
By their numbers in this assay, from the lowest: compound 4; then compound 2; then compounds 1 and 3 (each within the scatter of the next).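

In this assay, acetyl in place of methyl on the amine nitrogen gives a number 86.5 percentage points lower from compound 3 to compound 4 (beyond the scatter), so the large fall is no longer a single case tied to the allyl and the other nitrogen substituent of compound 1, where the earlier change gave a number 65.6 percentage points lower from compound 1 to compound 2 (beyond the scatter). With the saturated ring carbon of compound 4 on that nitrogen, the acetyl leaves compound 4 at -0.9%, which amounts to practically no inhibition at the one concentration tested. Nothing available here explains why this change has such an effect.

The compounds shown leave open whether the loss belongs to the acetyl itself or would also follow from another group on this nitrogen, such as a propanoyl or a methanesulfonyl. They also leave open how much inhibition survives with a longer chain such as butyl, or with a chain ending in an amine.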